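Adding a Second Methoxy Group to Compound 3

The compounds below may be only part of what the source reports. "The series", "measured", "known", "first", "only" and "open" are said of these compounds alone.

The measured compounds, with their values in an ADME assay on HepG2 cells (Homo sapiens) for cytotoxicity, read by trypan blue exclusion, with a stated time of 48 h, in the presence of a further agent that is not named here; on this read-out lower numbers stand for higher toxicity in this test and higher numbers for lower toxicity in this test:
Compound 1, `COc1ccc2nc(C)cc(OCC(=O)Nc3ccccc3)c2c1`, gives 118000 nM.
Compound 2, `COc1cccc(NC(=O)COc2cc(C)nc3ccc(OC)cc23)c1`, gives 24700 nM.
Compound 3, `COc1ccc(NC(=O)COc2cc(C)nc3ccc(OC)cc23)cc1`, gives > 142000 nM.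

For compound 3 that figure is a limit of this assay, not a number, so compound 3 stands only at or beyond (the limit of > 142000 nM in this assay, at which 1 of the 3 values shown sits).

The step from compound 3 to compound 4, `COc1ccc(NC(=O)COc2cc(C)nc3ccc(OC)cc23)c(OC)c1`, is methoxy in place of hydrogen on an aromatic carbon. Two measured steps are of the same kind, a methoxy replacing a hydrogen on the aromatic ring of the amide nitrogen: a 4.8-fold lower number from compound 1 to compound 2 (0.68 log units; beyond the scatter), whereas an at least 1.2-fold higher number from compound 1 to compound 3 (0.08 log units; that floor lies within the scatter). The same change therefore once lowered the number, once left it unchanged. A third step, an at least 5.7-fold higher number from compound 2 to compound 3 (0.75 log units; beyond the scatter), shows that where the methoxy sits matters.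

Since compound 3 is known only as a limit, the added methoxy in compound 4 is expected to bring the number down to a measurable value, or to leave it at the limit; the expected change is an at least 1.5-fold lower number from compound 3 to compound 4 (0.19 log units; that floor lies within the scatter). Compound 4 is thus estimated at 90000 nM, with a range from 25000 nM to 300000 nM.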

Compound 4, half-maximal cytotoxic concentration: > 131000 nM
Compound 4: no number, only a limit (the forecaster's own chance of this, stated with the estimate: 40%); middle value at least 1.4-fold (0.16 log units) away from the limit.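

In this assay compound 4 gives > 131000 nM, which is a limit and not a number. Compound 3 gives > 142000 nM, also a limit. With only these two limits, the step from compound 3 to compound 4 cannot be read. The compounds shown leave open whether the added methoxy changes the number at all.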